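Exchanging Butyl for Iodo in a Sulfonamide Series

The compounds below may be only part of what the source reports. "The series", "measured", "known", "first", "only" and "open" are said of these compounds alone.

Three sulfonamides sharing one core have been measured in a functional assay on HT-29 cells (Homo sapiens) for antiproliferative activity, read by sulforhodamine B assay, with a stated time of 48 h; a lower number here means a stronger inhibitor, a higher number a weaker inhibitor. There, compound 1 `CCc1ccccc1NS(=O)(=O)c1ccc(N2CCNC2=O)cc1` gives 240 nM, compound 2 `Cc1cccc(NS(=O)(=O)c2ccc(N3CCNC3=O)cc2)c1` gives 110 nM and compound 3 `CCCCc1ccc(NS(=O)(=O)c2ccc(N3CCNC3=O)cc2)cc1` gives 610 nM. Compound 3 therefore has the highest number of the three and is the weakest inhibitor among them. Compound 4 `O=C1NCCN1c1ccc(S(=O)(=O)Nc2ccc(I)cc2)cc1` has not yet been measured. It differs from compound 3 in one place: iodo in place of butyl on an aromatic carbon. This puts iodo in place of butyl on an aromatic carbon, para to a large group. For the measured compounds named here, only one measured step bears on this change, and only loosely, since it involves other groups: a 2.2-fold lower number from compound 1 to compound 2 (0.34 log units; beyond the scatter), a modest step. Going by the values given here, no measured compound carries iodo, so the data do not isolate this exchange. With compound 3 at 610 nM standing highest, a modest step toward a lower number is expected, a 2.0-fold lower number from compound 3 to compound 4 (0.31 log units; beyond the scatter). Compound 4 is estimated at 300 nM, with an expected range of 100 nM to 900 nM.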

Compound 4, half-maximal inhibitory concentration: 650 nM
Compound 4: middle estimate off by 2.2-fold (0.34 log units), on the low side; measured number inside the range.
By their numbers in this assay, from the lowest: compound 2; then compound 1; then compounds 3 and 4 (each within the scatter of the next).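

In this assay, one iodine atom takes the place of the four carbons of butyl on this aromatic carbon, para to a large group, and the result stays within the scatter (a 1.1-fold higher number from compound 3 to compound 4 (0.03 log units; within the scatter)). Compound 4 thus stands with compound 3 and clearly apart from the two compounds with other substituted phenyl groups on the sulfonamide nitrogen (a 5.9-fold higher number from compound 2 to compound 4 (0.77 log units; beyond the scatter); a 2.7-fold higher number from compound 1 to compound 4 (0.43 log units; beyond the scatter)). Nothing measured here explains why butyl and iodo give matching numbers.

On these data alone, it remains open whether an amine or a carboxylic acid at this same position would give a number like those of compound 3 and compound 4. As far as these compounds go, it is also open whether iodo placed elsewhere on this ring would give a number nearer those of compound 1 and compound 2.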